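The compounds below may be only part of what the source reports. "The series", "measured", "known", "first", "only" and "open" are said of these compounds alone.

Working notes on the series. In a functional assay on BE(2)-C cells (Homo sapiens) for inhibition, read by MTT assay, with a stated time of 72 h (on this read-out lower numbers stand for stronger inhibition of growth and higher numbers for weaker inhibition of growth), compound 1 `COc1ccc(CNCCCNS(=O)(=O)c2cc(C(F)(F)F)cc(C(F)(F)F)c2)cc1OC` gives 3600 nM, compound 2 `O=S(=O)(NCCCNCc1ccc(Cl)c(C(F)(F)F)c1)c1cc(C(F)(F)F)cc(C(F)(F)F)c1` gives 8600 nM and compound 3 `O=S(=O)(NCCCNCC1COc2ccccc2O1)c1cc(C(F)(F)F)cc(C(F)(F)F)c1` gives 2800 nM. Compound 3 holds the lowest of the three numbers, one gap being a 1.3-fold lower number from compound 1 to compound 3 (0.11 log units; within the scatter) and the other 3.1-fold lower number from compound 2 to compound 3 (0.49 log units; beyond the scatter). Compound 4 `O=S(=O)(NCCCNCc1ccc(C(F)(F)F)cc1)c1cc(C(F)(F)F)cc(C(F)(F)F)c1` differs from compound 3 by 4-(trifluoromethyl)phenyl in place of 2,3-dihydro-1,4-benzodioxin-2-yl on a saturated chain carbon bound to an amine nitrogen. For the measured compounds named here, the closest precedent runs the other way, a 3.1-fold lower number from compound 2 to compound 3 (0.49 log units; beyond the scatter), and a 2.4-fold higher number from compound 1 to compound 2 (0.38 log units; beyond the scatter) points in the same direction; the group entering here carries no chloro, so a somewhat smaller move is expected. A modest rise in this assay is therefore expected, a 2.0-fold higher number from compound 3 to compound 4 (0.29 log units; within the scatter). Compound 4 is estimated at 5500 nM, with a range from 2500 nM to 13000 nM.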

Compound 4, concentration for 50% growth inhibition: 2700 nM
Compound 4: middle estimate off by 2.0-fold (0.31 log units), on the high side; the range from low to high includes it.
By their numbers in this assay, from the lowest: compounds 4, 3 and 1 (each within the scatter of the next); then compound 2.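

In this assay, 4-(trifluoromethyl)phenyl and 2,3-dihydro-1,4-benzodioxin-2-yl cannot be told apart on this saturated chain carbon bound to an amine nitrogen, with a 1.0-fold lower number from compound 3 to compound 4 (0.02 log units; within the scatter). The same holds against 3,4-dimethoxyphenyl, with a 1.3-fold lower number from compound 1 to compound 4 (0.12 log units; within the scatter), whereas a 3.2-fold lower number from compound 2 to compound 4 (0.50 log units; beyond the scatter) shows that a trifluoromethyl group on the phenyl ring does not by itself go with the higher number of compound 2. No measurement at hand accounts for this difference. On these data alone, whether 4-chlorophenyl or plain phenyl here would sit with compound 4 or with compound 2 remains open. So does the effect of a longer chain in the shared core.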